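A few compounds are considered here, and "the series" means these few. Any claim that something is new, unique, unknown or untested is made for them only; others in the source may bear on it.

Compound 1 `Nc1ccccc1NC(=O)c1ccc(CSC(=S)N2CCc3ccccc32)cc1` was tested in a functional assay on MGC-803 cells (Homo sapiens) for antiproliferative activity, read by CCK-8 assay, with a stated time of 72 h, tested at 8 uM (a higher number here means a stronger effect of the compound at the concentration tested, a lower number a weaker effect), and compound 1 gives 87%. Among the compounds with values here, the only other measured compound is compound 2 `CN1CCN(C(=S)SCc2ccc(C(=O)Nc3ccccc3N)cc2)CC1`, which in this assay gives 84.4%. Within the data shown here, the single measured step, a number 2.6 percentage points lower from compound 1 to compound 2 (within the scatter), lies within the scatter, so the two numbers cannot be told apart, and compound 1 stands at the higher of two numbers that are practically the same.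

Compound 3 `Nc1ccccc1NC(=O)c1ccc(CSC(=S)N2CCc3ccc([N+](=O)[O-])cc32)cc1` differs from compound 1 by nitro in place of hydrogen on an aromatic carbon. Among the measured compounds shown here, no measured step bears on this change: the one known step exchanges the group on the thiocarbonyl carbon and leaves the fused ring untouched, and it was small in any case. With nothing in the data that points up or down, no step beyond the scatter is expected in this assay, and a value for compound 3 close to that of compound 1 is the natural expectation.

The estimated step of a number 5 percentage points lower from compound 1 to compound 3 (within the scatter) is therefore expected to stay small. Compound 3 is accordingly estimated at 82%, within a range from 65% to 93%.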

Compound 3, a percentage reported as inhibition, at one concentration (the size of the read-out at that concentration, not a potency): 39.6%
Estimate against measurement, compound 3: 42.4 percentage points above, outside the stated range (below it).
By their numbers in this assay, from the lowest: compound 3; then compounds 2 and 1 (each within the scatter of the next).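

The fused ring of the core is not a silent region in this assay: with nitro in place of hydrogen on an aromatic carbon of that ring, the data show a number 47.4 percentage points lower from compound 1 to compound 3 (beyond the scatter) and thus a large loss of the effect seen at the tested concentration. The earlier pair could not show this, since it changed only the group on the thiocarbonyl carbon and left the fused ring untouched, giving a number 2.6 percentage points lower from compound 1 to compound 2 (within the scatter) for that exchange. A single added group on this ring therefore matters far more here than the exchange on the thiocarbonyl carbon, and no measurement at hand explains why.

As far as these compounds go, with one group at one place, it remains open whether the loss belongs to nitro itself or would follow any group put on this carbon, such as an amine, a methoxy group or a fluorine atom. From the compounds shown here alone, it is equally open whether nitro on another carbon of the same ring would give a similar result, or whether the same change would act alike on the 4-methylpiperazin-1-yl compound 2.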